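The compounds below may be only part of what the source reports. "The series", "measured", "known", "first", "only" and "open" are said of these compounds alone.

Measured compounds:
compound 1, `N#Cc1ccc(-c2cnc3[nH]cc(-c4nnc(-c5ccc(F)cc5)o4)c(=O)c3c2)cc1`, in a functional assay on HCT-116 cells (Homo sapiens) for inhibition, read by MTT assay, with a stated time of 24 h, tested at 5 uM; a higher number here means more inhibition of growth at the concentration tested, a lower number less inhibition of growth: 12.6%
compound 2, `CS(=O)(=O)c1ccc(-c2cnc3[nH]cc(-c4nnc(-c5ccccc5)o4)c(=O)c3c2)cc1`, in this assay: 8.6%

Both readings are small, and compound 2 and compound 1 lie within the usual scatter of each other, so neither can be set above the other in this assay; compound 2 is simply one of two low readings. Compound 3, `Cc1cccc(-c2nnc(-c3c[nH]c4ncc(-c5ccc(S(C)(=O)=O)cc5)cc4c3=O)o2)c1`, has not yet been run in this assay. It differs from compound 2 in one place: methyl in place of hydrogen on an aromatic carbon. Going by the values given here, no pair of measured compounds that differ in one place is available, so the size of such a step in this assay is unknown from the data. With compound 2 at 8.6% and compound 1 at 12.6%, the expectation for compound 3 is no movement beyond the scatter. The value expected for compound 3 is 10%, with a range from 0% to 25%. The implied step, a number 1.4 percentage points higher from compound 2 to compound 3 (within the scatter), is expected to stay within the scatter.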

Compound 3, percent growth inhibition at one concentration: 20.4%
The estimate for compound 3 lay 10.4 percentage points below the measured number; the range from low to high includes it.
By their numbers in this assay, from the lowest: compounds 2, 1 and 3 (each within the scatter of the next, the first and the last beyond it).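

Going by these compounds alone, the step of a number 11.8 percentage points higher from compound 2 to compound 3 (beyond the scatter) in this assay is the first single-place change, and it lies beyond the scatter. It shows that this position, on a six-membered aromatic ring of carbon only and meta to a large group, is not silent: the change from phenyl to 3-methylphenyl, only 1 heavy atom, is enough to shift the reading, although compound 3 still gives only 20.4% at the concentration tested. Nothing available accounts for this shift.

As far as these compounds go, with a single step at a single place, it remains open whether the gain depends on methyl itself or would also appear with a methoxy group, an amine or a carboxylic acid there. From the compounds shown here alone, it is also open whether the same step would appear on the core of compound 1, which carries a nitrile.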